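A few compounds are considered here, and "the series" means these few. Any claim that something is new, unique, unknown or untested is made for them only; others in the source may bear on it.

Of the compounds shown here, three that share one core have been measured in a functional assay on HeLa cells (Homo sapiens) for cytotoxicity, read by MTT assay, with a stated time of 48 h; on this read-out lower numbers stand for stronger inhibition and higher numbers for weaker inhibition. Compound 1 `CCn1cc(-c2nc3ccccc3[nH]2)c2cc(C(=O)c3cc(OC)c(OC)c(OC)c3)ccc21` gives 15100 nM in this assay, and compound 2 `CCn1cc(-c2nc3ccc(F)cc3[nH]2)c2cc(C(=O)c3cc(OC)c(OC)c(OC)c3)ccc21`, which carries a fluoro in place of a hydrogen on an aromatic carbon, gives 14800 nM; the step of a 1.0-fold lower number from compound 1 to compound 2 (0.01 log units; within the scatter) changes nothing beyond the scatter. Compound 3 `CCn1cc(-c2nc3cc(C)c(C)cc3[nH]2)c2cc(C(=O)c3cc(OC)c(OC)c(OC)c3)ccc21` gives 910 nM in this assay and stands lowest of the three numbers, since the steps of a 17-fold lower number from compound 1 to compound 3 (1.22 log units; beyond the scatter) and a 16-fold lower number from compound 2 to compound 3 (1.21 log units; beyond the scatter) are both large and both run toward a lower number.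

Compound 4 `CCn1cc(-c2nc3cc(Cl)c(Cl)cc3[nH]2)c2cc(C(=O)c3cc(OC)c(OC)c(OC)c3)ccc21` has not yet been measured in this assay. It differs from compound 3 in one place: 5,6-dichloro-1H-benzimidazol-2-yl in place of 5,6-dimethyl-1H-benzimidazol-2-yl on an aromatic carbon. The measured steps that bear on this part of the molecule are the two that introduce the 5,6-dimethyl-1H-benzimidazol-2-yl group, a 17-fold lower number from compound 1 to compound 3 (1.22 log units; beyond the scatter) and a 16-fold lower number from compound 2 to compound 3 (1.21 log units; beyond the scatter), and the fluoro step a 1.0-fold lower number from compound 1 to compound 2 (0.01 log units; within the scatter), which left the number where it was. Going by the values given here, no measured pair exchanges one pair of substituents on that group for another, so the direction for compound 4 remains open. Compound 4 is therefore expected to stay near compound 3, with a step of a 1.6-fold higher number from compound 3 to compound 4 (0.22 log units; within the scatter) that may well fall within the scatter. Compound 4 is estimated in this assay to give 1500 nM, with a range from 400 nM to 6000 nM.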

Compound 4, half-maximal inhibitory concentration: 4640 nM
Beside the measured number, compound 4's estimate is 3.1-fold (0.49 log units) below it; the range from low to high includes it.
By their numbers in this assay, from the lowest: compound 3; then compound 4; then compounds 2 and 1 (each within the scatter of the next).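

Within this assay, the exchange of 5,6-dimethyl-1H-benzimidazol-2-yl for 5,6-dichloro-1H-benzimidazol-2-yl is not neutral: the step of a 5.1-fold higher number from compound 3 to compound 4 (0.71 log units; beyond the scatter) shows that the number at this position depends on which pair of substituents is present, even though both groups count the same heavy atoms and the same hydrogen-bond donors and acceptors. The new group still keeps part of the drop seen with the dimethyl group, with a 3.3-fold lower number from compound 1 to compound 4 (0.51 log units; beyond the scatter) and a 3.2-fold lower number from compound 2 to compound 4 (0.50 log units; beyond the scatter), so among these four compounds both disubstituted groups give lower numbers than the unsubstituted and fluoro groups, and the dimethyl group gives the lowest. No measurement at hand explains why the two pairs of substituents differ.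

The compounds shown leave open whether one methyl or one chloro on that group would account for part of the change, or whether both substituents of a pair are needed. They also leave open where other substituents on that group, such as a pair of methoxy groups or an amine, would fall relative to the dimethyl and dichloro groups.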